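Cytotoxicity notes on the benzyladenosine series

A few compounds are considered here, and "the series" means these few. Any claim that something is new, unique, unknown or untested is made for them only; others in the source may bear on it.

Compound 2 `Cc1ccc(CNc2ncnc3c2ncn3[C@@H]2O[C@H](CO)[C@@H](O)[C@H]2O)cc1` sits at the limit of an ADME assay on NIH3T3 cells (Mus musculus) for cytotoxicity, with a stated time of 72 h (on this read-out higher numbers stand for weaker inhibition and lower numbers for stronger inhibition), giving > 166000 nM, a limit rather than a number. Compound 1 `OC[C@H]1O[C@@H](n2cnc3c(NCc4ccc(Cl)cc4)ncnc32)[C@H](O)[C@@H]1O` likewise gives a limit, > 166000 nM. Compound 3 `COc1cc(CNc2ncnc3c2ncn3[C@@H]2O[C@H](CO)[C@@H](O)[C@H]2O)cc(OC)c1` has "not determined" (no result reported) in this assay. For the measured compounds named here, the one measured step, a step that the two limits leave unreadable from compound 1 to compound 2, is unreadable because of the limit of > 166000 nM in this assay, at which 2 of the 3 values shown sit. Compound 4 `OC[C@H]1O[C@@H](n2cnc3c(NCc4ccc(F)cc4Cl)ncnc32)[C@H](O)[C@@H]1O` differs from compound 2 by 2-chloro-4-fluorophenyl in place of 4-methylphenyl on a saturated chain carbon bound to a nitrogen on an aromatic ring. Going by the values given here, no measured step bears on this change, and with compound 2 at the limit, the step that the limit leaves unreadable from compound 2 to compound 4 is expected to stay within the scatter. Compound 4 is therefore estimated at 200000 nM in this assay, in the range 100000 nM to 400000 nM, most likely reported again only as a limit.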

Compound 4, half-maximal inhibitory concentration: > 166000 nM
Compound 4 ended at the assay's limit; the forecaster's own chance of this, stated with the estimate: 80%; the middle value lies beyond the limit too.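

Compound 4 joins compound 1 and compound 2 at the limit, so no step among these three compounds can be read: the limit of > 166000 nM in this assay, at which 3 of the 4 values shown sit.

From the compounds shown here alone, whether their benzyl groups differ at all in this assay stays open.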